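A Small Ring Substituent in Place of Butoxy

The source may hold more compounds than are shown below. What is called first, only, known or untested is meant among the compounds shown, and "the series" means these compounds.

Compound 1 `CCOc1ccccc1C[C@H]1COC(=O)[C@@H]1Cc1ccc(Cl)c(Cl)c1`: 15000 nM
Compound 2 `CCCCOc1ccccc1C[C@H]1COC(=O)[C@@H]1Cc1ccc(Cl)c(Cl)c1`: 10000 nM
Compound 3 `O=C1OC[C@H](Cc2ccccc2F)[C@H]1Cc1ccc(Cl)c(Cl)c1`: not yet measured

In a functional assay on HL-60 cells (Homo sapiens) for cytotoxicity, read by WST assay, with a stated time of 48 h (on this read-out higher numbers stand for an effect only at larger amounts of compound and lower numbers for an effect already at smaller amounts), compound 2 gives 10000 nM, which cannot be told apart from the value of compound 1, 15000 nM. Compound 3 `O=C1OC[C@H](Cc2ccccc2F)[C@H]1Cc1ccc(Cl)c(Cl)c1` keeps the shared core but carries fluoro in place of butoxy on an aromatic carbon. Among the compounds with values here, only one measured step touches this group, a 1.5-fold lower number from compound 1 to compound 2 (0.18 log units; within the scatter). That step altered only the length of the chain, so it guides a swap of the whole group only loosely. Within the data shown here, no compound with fluoro has been measured, which keeps the range wide. A step beyond the scatter is not expected, with only a slight lean towards a higher number in this assay. The expected move is a 1.8-fold higher number from compound 2 to compound 3 (0.26 log units; within the scatter). Compound 3 is estimated at 18000 nM, with an expected range of 8000 nM to 45000 nM.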

Compound 3, half-maximal effective concentration: 28000 nM
Beside the measured number, compound 3's estimate is 1.6-fold (0.19 log units) below it; measured number inside the range.
By their numbers in this assay, from the lowest: compounds 2, 1 and 3 (each within the scatter of the next, the first and the last beyond it).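

In this assay, within the data shown here, fluoro in place of butoxy on an aromatic carbon gives a 2.8-fold higher number from compound 2 to compound 3 (0.45 log units; beyond the scatter), the first step to lie beyond the usual scatter, though it is a modest one. Fluoro in place of ethoxy gives a 1.9-fold higher number from compound 1 to compound 3 (0.27 log units; within the scatter), so only the butoxy and fluoro compounds can be told apart, while the ethoxy compound cannot be separated from either. Nothing available here explains this shift.

As far as these compounds go, it remains open whether a methoxy group or an amine at this place would give a number closer to that of the fluoro compound or the butoxy compound. A chain longer than butoxy would show whether the number keeps falling as the group grows.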